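Methoxy for Trifluoromethyl on Two Related Two-Ring Cores

The source may hold more compounds than are shown below. What is called first, only, known or untested is meant among the compounds shown, and "the series" means these compounds.

Three compounds were tested in a functional assay on the whole organism (strain Sprague-Dawley) for inhibition, with Rattus norvegicus as the target; a lower number here means that less compound is needed, a higher number that more compound is needed for the effect. Compound 1 `COc1cccc2cc(-c3nn[nH]n3)cnc12` gives 2.5 mg/kg in this assay. Compound 3 `FC(F)(F)c1cccc2cc(-c3nn[nH]n3)cnc12` reaches only a limit of the assay, < 25 mg/kg. Compound 2 `O=C(O)c1cnc2cc(C(F)(F)F)ccc2c1` also stops at a limit of the assay, > 25 mg/kg. The change from compound 3 to compound 1 is methoxy in place of trifluoromethyl on an aromatic carbon, and the step it made is a step that the limit leaves unreadable from compound 3 to compound 1 because the limit of < 25 mg/kg in this assay, at which 1 of the 3 values shown sits, leaves its size unreadable. Compound 4 `COc1ccc2cc(C(=O)O)cnc2c1` arises from compound 2 by methoxy in place of trifluoromethyl on an aromatic carbon, the same kind of change, but here the carbon is meta to a fused ring and para to a fused ring rather than ortho and meta. The difference between the two cores is not broken down here. Because compound 2 sits at the limit of > 25 mg/kg in this assay, at which 1 of the 3 values shown sits, the expected step is a number no higher from compound 2 to compound 4 (the limit leaves the size open). Compound 4 is therefore estimated at 25 mg/kg, within 5 mg/kg to 100 mg/kg.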

Compound 4, minimum effective dose: > 25 mg/kg
Compound 4: only a limit was reported; the forecaster's own chance of this, stated with the estimate: 60%; the middle value sits exactly at the limit.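

Among the compounds shown here, compound 2 and compound 4 both stop at a limit of the assay, so no step between them can be read: the limit of > 25 mg/kg in this assay, at which 2 of the 4 values shown sit. The compounds shown leave open how far methoxy in place of trifluoromethyl shifts the minimum effective dose on either core.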